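From compound 3 to compound 4: one added methyl

The source may report more compounds than this note shows. Statements on the series, on what has been measured and on what is new or still open speak of the compounds shown alone.

Measured in an ADME assay on HEK293 cells (Homo sapiens) for cytotoxicity, read by ATP content, with a stated time of 6 h; a lower number here means that less compound is tolerated, a higher number that more compound is tolerated:
- compound 1 `Cc1ccc(CNc2nc(N)nc3ccn(Cc4ccccn4)c23)nc1`: > 24000 nM, a limit
- compound 2 `CC(Nc1nc(N)nc2ccn(Cc3ccccn3)c12)c1ccccn1`: > 24000 nM, a limit
- compound 3 `Nc1nc(NCc2ncco2)c2c(ccn2Cc2ccccn2)n1`: > 24000 nM, a limit

All three readings are the same limit and not numbers: the limit of > 24000 nM in this assay, at which 3 of the 3 values shown sit. Compound 3 therefore stands at this limit, with no number of its own.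

Compound 4 `Cc1coc(CNc2nc(N)nc3ccn(Cc4ccccn4)c23)n1` has methyl in place of hydrogen on an aromatic carbon, which turns the 1,3-oxazol-2-yl group of compound 3 into 4-methyl-1,3-oxazol-2-yl (methyl in place of hydrogen on an aromatic carbon). For the measured compounds named here, no measured step covers this methyl. The nearest evidence is a step that the two limits leave unreadable from compound 1 to compound 3, a step that the two limits leave unreadable from compound 2 to compound 3 and a step that the two limits leave unreadable from compound 1 to compound 2. None of these has a readable size, yet each links compounds that stay at the limit in this assay. On that basis, no change beyond the usual scatter is expected, and a further limit is the likeliest report. The expected step is a step that the limit leaves unreadable from compound 3 to compound 4. For compound 4 the estimated value is 30000 nM. The estimated range for compound 4 runs from 15000 nM to 60000 nM.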

Compound 4, half-maximal cytotoxic concentration: > 24000 nM
Compound 4 ended at the assay's limit; the forecaster's own chance of this, stated with the estimate: 85%; the middle value is on the limit's open side.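

In this assay compound 4 gives > 24000 nM as a limit and not a number. For the compounds shown here, no step from compound 1, compound 2 or compound 3 to compound 4 can be read: the limit of > 24000 nM in this assay, at which 4 of the 4 values shown sit. What the compounds shown leave open is whether the added methyl, or any other difference among these four compounds, shifts the half-maximal cytotoxic concentration at all.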